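Replacing isobutyl by 1-(methoxymethyl)ethyl on the ring amine

This account rests on a few compounds, and the source may have more. Where it says the series, first, only, none or still open, it means among the compounds named here.

Going by the values given here, compound 2 `COc1cccc(-n2cc3nc(-c4cccnc4C)n(C[C@H]4CCCN(CC(C)C)C4)c(=O)c3n2)c1` gives 5.7 nM in an assay on HEK293 cells for displacement of a labelled ligand from growth hormone secretagogue receptor type 1 (Homo sapiens), with a stated time of 60 min (on this read-out higher numbers stand for weaker inhibition and lower numbers for stronger inhibition), the lowest of the two numbers so far; compound 1 `COc1cccc(-n2cc3nc(-c4cccnc4C)n(C[C@H]4CCCN(CC5CCCCO5)C4)c(=O)c3n2)c1` gives 120 nM, and the step of a 21-fold lower number from compound 1 to compound 2 (1.32 log units; beyond the scatter) was large. Compound 3 `COC[C@H](C)N1CCC[C@H](Cn2c(-c3cccnc3C)nc3cn(-c4cccc(OC)c4)nc3c2=O)C1` carries the change (1-(methoxymethyl)ethyl in place of isobutyl on an amine nitrogen in a ring). Among the compounds with values here, the only step that bears on it is a 21-fold lower number from compound 1 to compound 2 (1.32 log units; beyond the scatter), where removing an oxygen-bearing group lowered the number strongly; bringing an oxygen back, though in a smaller chain, is expected to raise the number modestly, as a 2.6-fold higher number from compound 2 to compound 3 (0.42 log units; beyond the scatter). Compound 3 is therefore estimated at 15 nM, between 5 nM and 50 nM.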

Compound 3, half-maximal inhibitory concentration: 1.7 nM
For compound 3 the middle estimate is 8.8-fold (0.95 log units) above the measured one; measured number outside the range, below it.
By their numbers in this assay, from the lowest: compound 3; then compound 2; then compound 1.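

In this assay, 1-(methoxymethyl)ethyl on the amine nitrogen gives a 3.4-fold lower number from compound 2 to compound 3 (0.53 log units; beyond the scatter) and so outdoes isobutyl, showing that an oxygen-bearing group at this position can lower the number. Against (oxan-2-yl)methyl, the same group gives a 71-fold lower number from compound 1 to compound 3 (1.85 log units; beyond the scatter) here. The data offer no explanation for these steps. Going by these compounds, it remains open whether the oxygen or the defined stereocentre matters, and how the opposite configuration, or a hydroxy or dimethylamino group replacing the methoxy, would read.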